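A few compounds are considered here, and "the series" means these few. Any claim that something is new, unique, unknown or untested is made for them only; others in the source may bear on it.

Of the compounds shown here, three of a shared core have been measured in an assay on Ltk cells with metabotropic glutamate receptor 5 (Homo sapiens) as the target, read by fluorescence and calcium flux; a lower number here means a stronger inhibitor, a higher number a weaker inhibitor. Compound 1 `Cc1cccc(Nc2ncccc2OC(C)C)n1` gives 1000 nM in this assay, and compound 2 `CCOc1nccnc1Nc1cccc(C)n1` gives 497 nM. Compound 3 `CCOc1cc(C#N)cnc1Nc1cccc(C)n1` gives 46 nM, the lowest number of the three; its gaps to compound 2 and to compound 1 both lie beyond the usual scatter of repeated measurements, so compound 3 stands as the strongest inhibitor among the measured compounds.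

Compound 4 `CCOc1cc(Oc2cccnc2)cnc1Nc1cccc(C)n1` has not yet been measured. It differs from compound 3 in one place: (pyridin-3-yl)oxy in place of cyano on an aromatic carbon. Within the data shown here, no step between measured compounds follows this kind of change, so there is no precedent here for its size or direction. On the numbers shown, the expectation for compound 4 in this assay is a step that stays close to compound 3, expected as a 1.7-fold higher number from compound 3 to compound 4 (0.24 log units; within the scatter) and not clearly beyond the scatter in either direction. Compound 4 is therefore estimated at 80 nM, with a range from 20 nM to 400 nM.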

Compound 4, half-maximal inhibitory concentration: 18 nM
Beside the measured number, compound 4's estimate is 4.4-fold (0.65 log units) above it; the whole stated range lies above it.
By their numbers in this assay, from the lowest: compound 4; then compound 3; then compounds 2 and 1 (each within the scatter of the next).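

At this place on the ring, two atoms from the ring nitrogen, putting (pyridin-3-yl)oxy in place of cyano gives a 2.6-fold lower number from compound 3 to compound 4 (0.41 log units; beyond the scatter) in this assay and so does not cost strength. The cyano is therefore not needed for a low number here, and a much larger group that brings a six-membered aromatic ring of its own can stand in its place, with a step beyond the scatter. Nothing shown gives a measured reason for this step.

On these data alone, what remains open is whether the nitrogen of the entering ring matters, which phenoxy or (pyridin-4-yl)oxy at the same place would test. As far as these compounds go, it is also open whether the oxygen link matters, which a pyridine ring attached directly or through an amine would show.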